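The compounds below may be only part of what the source reports. "The series", "measured", "known", "first", "only" and "open" are said of these compounds alone.

In a functional assay for inhibition, with Homo sapiens as the target (a lower number here means a stronger inhibitor, a higher number a weaker inhibitor), compound 1 `CCCCS(=O)(=O)N[C@@H](CNC(=O)c1ccc2c(c1)C(=O)N(CCC1CCNCC1)C2)C(=O)O` gives 14 nM; 9 nM (2 entries). Going by the values given here, compound 2 `CCCCNC(=O)N[C@@H](CNC(=O)c1ccc2c(c1)C(=O)N(CCC1CCNCC1)C2)C(=O)O` gives 16 nM, the only single number for it, alongside one further entry without a single number. These values lie within the usual scatter of each other. Compound 3 `O=C(O)c1ccc(S(=O)(=O)N[C@@H](CNC(=O)c2ccc3c(c2)C(=O)N(CCC2CCNCC2)C3)C(=O)O)cc1` is reached from compound 2 by (4-carboxyphenyl)sulfonyl in place of butylcarbamoyl on an amine nitrogen. Among the compounds with values here, no measured step covers this swap, but compound 1, at 14 nM; 9 nM (2 entries), also has a sulfonyl group on that nitrogen, so only a modest weakening is expected. The expected change is a 1.9-fold higher number from compound 2 to compound 3 (0.27 log units; within the scatter). For compound 3 the estimate is 30 nM, with a range of 8 nM to 120 nM.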

Compound 3, half-maximal inhibitory concentration: 7 nM
For compound 3 the middle estimate is 4.3-fold (0.63 log units) above the measured one; the measured number lies below the stated range.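

In this assay, going by these compounds alone, this amine nitrogen, which carried only butyl-based groups in the earlier compounds, also accepts a group with a six-membered aromatic ring: (4-carboxyphenyl)sulfonyl in place of butylcarbamoyl gives a 2.3-fold lower number from compound 2 to compound 3 (0.36 log units; beyond the scatter). The size of this step is modest. Compound 1 also has a sulfonyl group on this nitrogen, and no order between it and compound 3 is claimed here, given the spread in its repeat values: the several entries of compound 1 in this assay, 14 nM; 9 nM (2 entries)

The compounds shown leave open whether the ring alone or its carboxylic acid accounts for the step. A plain phenylsulfonyl group on this nitrogen would separate the two.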